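Swapping the Phenyl Tail for a Nitrile Group

This account rests on a few compounds, and the source may have more. Where it says the series, first, only, none or still open, it means among the compounds named here.

Compound 1 `O=C(O)CCc1ccc(NCc2ccc(-c3ccccc3)cc2)cc1` is tested in a functional assay on CHO cells for agonist activity at Free fatty acid receptor 1 (Homo sapiens), read by reporter gene assay (a higher number here means a larger maximal response, a lower number a smaller maximal response), where compound 1 gives 111%. Among the three measured compounds, compound 1 stands second highest. Its nearest neighbour is compound 3 `O=C(O)CCc1ccc(NCc2cccc(Br)c2)cc1`, which in this assay gives 120%, a gap that stays within the usual scatter. Furthest away is compound 2 `O=C(O)CCCc1ccc(NCc2ccc(-c3ccccc3)cc2)cc1`, which in this assay gives 62%; the step of a number 49 percentage points lower from compound 1 to compound 2 (beyond the scatter) is beyond the scatter and accompanies carboxymethyl in place of carboxy on a saturated chain carbon, two bonds along the chain from an aromatic carbon.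

Compound 4 `N#Cc1ccc(CNc2ccc(CCC(=O)O)cc2)cc1` has not yet been measured. It differs from compound 1 in one place: cyano in place of phenyl on an aromatic carbon, on an aromatic carbon of a six-membered aromatic ring of carbon only, para to a large group. For the measured compounds named here, no measured step alters this part of the molecule; the single known step concerns the acid chain and so does not bear directly on it. The values of compound 1 and compound 3, which carry different groups on that ring, differ only within the scatter, so a different group at this end did not move the maximal response beyond it. Compound 4 is therefore expected to give about 105%, between 75% and 130%. This estimate means an expected step of a number 6 percentage points lower from compound 1 to compound 4 (within the scatter), which should stay within the scatter.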

Compound 4, largest response reached (reported as percent of maximum), in percent of the reference or control that the assay uses: 49%
The estimate for compound 4 lay 56 percentage points above the measured number; measured number below the stated range.
By their numbers in this assay, from the lowest: compound 4; then compound 2; then compounds 1 and 3 (each within the scatter of the next).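

In this assay, replacing phenyl with cyano on an aromatic carbon, para to a large group, gives a number 62 percentage points lower from compound 1 to compound 4 (beyond the scatter), so the group at this position has a strong bearing on the maximal response. The earlier compounds shown here showed a large change only in the acid chain, a number 49 percentage points lower from compound 1 to compound 2 (beyond the scatter), whereas this result shows that a single change at the opposite end of the molecule can also produce a large step. The swap removes a phenyl group with its six-membered aromatic ring, along with six heavy atoms, and brings in a cyano group with two heavy atoms and one hydrogen-bond acceptor, but no available data show which of these differences matters.

From the compounds shown here alone, it remains open whether the response depends on keeping an aromatic ring at this position or whether the nitrile itself is the unfavourable part. Compounds with a cyclohexyl group, a methoxy group or a chlorine atom at this same position, each on the otherwise unchanged core of compound 1, would help separate these two possibilities.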